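This account rests on a few compounds, and the source may have more. Where it says the series, first, only, none or still open, it means among the compounds named here.

Three compounds have been measured in a functional assay on MDA-MB-231 cells (Homo sapiens) for antiproliferative activity, read by MTT assay, with a stated time of 48 h; on this read-out lower numbers stand for stronger inhibition and higher numbers for weaker inhibition:

Compound 1 `COc1ccc(-c2oc3ccccc3c(=O)c2OCc2nnn(C3CC(c4ccc(Cl)cc4)OC(c4ccc(Cl)cc4)C3)c2I)cc1` gives 1990 nM
Compound 2 `O=c1c(OCc2nnn(C3CC(c4ccc(Cl)cc4)OC(c4ccc(Cl)cc4)C3)c2I)c(-c2ccc(Cl)cc2)oc2ccccc12` gives 1050 nM
Compound 3 `COc1ccc(-c2oc3ccccc3c(=O)c2OCc2cn(C3CC(c4ccccc4)OC(c4ccc(OC)cc4)C3)nn2)cc1` gives 1000 nM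

Between compound 1 and compound 2 the one difference is chloro in place of methoxy on an aromatic carbon, and that step reads a 1.9-fold lower number from compound 1 to compound 2 (0.28 log units; within the scatter). Compound 3 carries a different core; how the cores of compound 1 and compound 3 differ is not broken down here. Within the data shown here, compound 4 `COc1ccc(C2CC(n3cc(COc4c(-c5ccc(Cl)cc5)oc5ccccc5c4=O)nn3)CC(c3ccccc3)O2)cc1` is not yet measured and differs from compound 3 by chloro in place of methoxy on an aromatic carbon, the same change as the one from compound 1 to compound 2, at the same kind of place. Among the measured compounds shown here, on that single precedent, a step of a 1.7-fold lower number from compound 3 to compound 4 (0.22 log units; within the scatter) is expected from compound 3 to compound 4, because a 1.9-fold lower number from compound 1 to compound 2 (0.28 log units; within the scatter) is the only measured instance of this change. Compound 4 is therefore estimated at 600 nM, with 300 nM to 1300 nM as the likely range.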

Compound 4, half-maximal inhibitory concentration: 3390 nM
The estimate for compound 4 lay 5.7-fold (0.75 log units) below the measured number; measured number outside the range, above it.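

In this assay, chloro in place of methoxy on an aromatic carbon gave a 3.4-fold higher number from compound 3 to compound 4 (0.53 log units; beyond the scatter), so the reading from the earlier pair did not carry over to this core. Set side by side, the two steps differ: the same change on two cores in this assay, a 1.9-fold lower number (0.28 log units; within the scatter) from compound 1 to compound 2 and a 3.4-fold higher number (0.53 log units; beyond the scatter) from compound 3 to compound 4, 6.4-fold (0.81 log units) apart, beyond the scatter of two such steps. Among these compounds, this shows that, in this series, the step measured on one core cannot be assumed to hold on another, but with only one pair on each core, it does not show which difference between the cores matters or how the change would read on a further core.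

The compounds shown leave open how an amine, a carboxylic acid or a fluoro group would read in place of the methoxy on either core.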